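This account rests on a few compounds, and the source may have more. Where it says the series, first, only, none or still open, it means among the compounds named here.

Measured compounds:
Compound 1 `O=C(NCc1ccc(CNS(=O)(=O)c2cccc(C(F)(F)F)c2)cc1)c1ccc(F)cc1`, which in an assay on MDA-MB-231 cells for binding affinity to C-X-C chemokine receptor type 4 (Homo sapiens), read by fluorescence and microscopy, with stated times of 10 min and 30 min (on this read-out lower numbers stand for an effect already at smaller amounts and higher numbers for an effect only at larger amounts of compound), gives 100 nM.
Compound 2 `O=C(NCc1ccc(CNS(=O)(=O)c2ccc3c(c2)CCO3)cc1)c1ccc(F)cc1`, which in this assay gives 10 nM.

Compound 1 stands highest of the two numbers shown. Its nearest neighbour is compound 2, reached by a 10-fold lower number from compound 1 to compound 2 (1.00 log units; beyond the scatter), a step in which a group of 9 heavy atoms takes the place of a group of 10 heavy atoms on a sulfonyl sulfur.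

Compound 3 `O=C(NCc1ccc(CNS(=O)(=O)c2ccc(F)c(F)c2)cc1)c1ccc(F)cc1` has not yet been measured. It differs from compound 1 in one place: 3,4-difluorophenyl in place of 3-(trifluoromethyl)phenyl on a sulfonyl sulfur. Among the compounds with values here, only one measured step bears on this change, a 10-fold lower number from compound 1 to compound 2 (1.00 log units; beyond the scatter), and that step brings in a different group at the same sulfonyl sulfur. It shows that a change at this position can move the number by a modest amount, but it gives no direct guide to 3,4-difluorophenyl. The step expected from compound 1 to compound 3 is therefore estimated as small, a 1.4-fold lower number from compound 1 to compound 3 (0.15 log units; within the scatter), toward a lower number if anything, and it may well stay within the scatter. Compound 3 is estimated at 70 nM, with a range from 20 nM to 300 nM.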

Compound 3, effective concentration (reported as EC, without a stated level of effect): 10 nM
For compound 3 the middle estimate is 7.0-fold (0.85 log units) above the measured one; the whole stated range lies above it.
By their numbers in this assay, from the lowest: compounds 2 and 3 (each within the scatter of the next); then compound 1.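

Replacing 3-(trifluoromethyl)phenyl on the sulfonyl sulfur with 3,4-difluorophenyl gives a 10-fold lower number from compound 1 to compound 3 (1.00 log units; beyond the scatter) in this assay, so this position responds to a change that keeps a six-membered aromatic ring of carbon only and fluorine as the sole added element. Within the data shown here, until now, the only lower number at this position came with a group containing a five-membered non-aromatic ring with an oxygen atom, and that ring proves not to be needed to reach this level: the step between the two replacement groups is no change at the digits printed from compound 2 to compound 3 (within the scatter). Thus, both groups that replace 3-(trifluoromethyl)phenyl give a lower number than compound 1, although they differ in their rings and heavy atoms, and no evidence is available to explain this result.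

The compounds shown leave open how unsubstituted phenyl would compare, and whether a phenyl ring carrying a methoxy group, an amine or a carboxylic acid would stay at the level of compound 2 and compound 3 or return toward that of compound 1. They also leave open whether the same steps would hold if the rest of the shared core were changed, since all three compounds differ only on the sulfonyl sulfur.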